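Shortening the alkyl chain on a shared core

The source may report more compounds than this note shows. Statements on the series, on what has been measured and on what is new or still open speak of the compounds shown alone.

Measured so far:
compound 1 `CCCCCc1nnc2nnc(N3CCCC3)nn12`: 27900 nM
compound 2 `CC(C)c1nnc2nnc(N3CCCC3)nn12`: 3430 nM

Both compounds were tested in a functional assay on BeWo cells (Homo sapiens) for cytotoxicity, read by MTT assay, with a stated time of 72 h; a lower number here means a stronger inhibitor, a higher number a weaker inhibitor. Going by the values given here, compound 2 has the lowest of the two numbers; the only measured step, an 8.1-fold lower number from compound 1 to compound 2 (0.91 log units; beyond the scatter), shows what happened when the chain on the core was shortened and branched.

Compound 3 `CCc1nnc2nnc(N3CCCC3)nn12` shares this core. Its change from compound 2 is hydrogen in place of methyl on a saturated chain carbon bound to an aromatic carbon and a saturated chain carbon. Among the compounds with values here, this is again a shortening of the chain at the same spot, so the one step that bears on it is an 8.1-fold lower number from compound 1 to compound 2 (0.91 log units; beyond the scatter), a modest gain when pentyl gave way to isopropyl. That single step says only that a shorter chain has so far gone together with a lower number; whether the trend continues from isopropyl to ethyl cannot be told from two compounds, and the change here is smaller.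

Compound 3 is therefore expected to give 2500 nM, within 800 nM to 8000 nM. The estimated step of a 1.4-fold lower number from compound 2 to compound 3 (0.14 log units; within the scatter) is expected to stay close to the scatter.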

Compound 3, half-maximal inhibitory concentration: 5020 nM
Compound 3: middle estimate off by 2.0-fold (0.30 log units), on the low side; measured number inside the range.
By their numbers in this assay, from the lowest: compounds 2 and 3 (each within the scatter of the next); then compound 1.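

In this assay, the change from isopropyl to ethyl gives a 1.5-fold higher number from compound 2 to compound 3 (0.17 log units; within the scatter), so removing this one methyl leaves the two compounds indistinguishable, and the shorter chain brings no further gain here. The ethyl compound still stands clearly apart from the pentyl compound, with a 5.6-fold lower number from compound 1 to compound 3 (0.74 log units; beyond the scatter), which shows that a branched chain is not needed for the lower number: an unbranched short chain at this position serves as well as isopropyl, and among these three compounds it is the pentyl compound that stands out. Nothing measured here explains why the pentyl chain gives the higher number or why ethyl and isopropyl cannot be told apart.

Still open, going by these compounds, is where the number begins to climb between ethyl and pentyl, which a propyl or butyl chain at this position could help to settle. It is also unknown whether a smaller methyl group, a small ring such as cyclopropyl, or a chain ending in an amine would stay level with ethyl and isopropyl or move away from them.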